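The source may report more compounds than this note shows. Statements on the series, on what has been measured and on what is new or still open speak of the compounds shown alone.

Series notes. Of the compounds shown here, three on the shared core have been measured in an assay for inhibition of 4-hydroxyphenylpyruvate dioxygenase (Sus scrofa); a lower number here means a stronger inhibitor, a higher number a weaker inhibitor. Compound 1 `O=C1CCCC(=O)C1C(=O)C1CCCCC1` gives 365000 nM, compound 3 `CCC(=O)C1C(=O)CCCC1=O` gives 17800 nM, and compound 2 `Cc1ccccc1C(=O)C1C(=O)CCCC1=O` gives 3750 nM. On these numbers compound 2 stands lowest of the three, with compound 3 the nearest and compound 1 the furthest, both gaps beyond the scatter.

Compound 4 `O=C1CCCC(=O)C1C(=O)c1ccccc1Cl` is not yet measured. It differs from compound 2 by chloro in place of methyl on an aromatic carbon. Going by the values given here, no measured pair shows this change, so its size rests on expectation only. The expectation for compound 4 in this assay is a modest step downward, a 2.5-fold lower number from compound 2 to compound 4 (0.40 log units; beyond the scatter), small enough that it may still fall within the scatter. Compound 4 is estimated at 1500 nM, with a range from 400 nM to 6000 nM.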

Compound 4, half-maximal inhibitory concentration: 500 nM
Compound 4: the middle estimate sits 3.0-fold (0.48 log units) above what was measured, within the range that was stated.
By their numbers in this assay, from the lowest: compound 4; then compound 2; then compound 3; then compound 1.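

In this assay, going by these compounds alone, chloro in place of methyl on an aromatic carbon ortho to a large group gives a 7.5-fold lower number from compound 2 to compound 4 (0.88 log units; beyond the scatter) and is the first measured single-place step. It shows that this position responds to the exchange of one heavy atom for another, with no change in ring count, hydrogen-bond donors, hydrogen-bond acceptors or net charge. Nothing available bears on the reason for this step. Still open, going by these compounds, is how a methoxy group, an amine or a bromo group would compare at this same place, and whether chloro on another aromatic carbon would give a similar step.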